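Swapping Isopropyl for 2-Fluorocyclopropyl on an Amide Core

The compounds below may be only part of what the source reports. "The series", "measured", "known", "first", "only" and "open" are said of these compounds alone.

The measured compounds and their values:

compound 1, `CCC(=O)N1CC2CC(C1)N2`: 110%
compound 2, `CC(C)C(=O)N1CC2CC(C1)N2`: 71%
compound 3, `O=C(C1CCCC1)N1CC2CC(C1)N2`: 68%

All three share one core and differ only in the group on the carbonyl carbon. In an assay on SH-EP1 cells for agonist activity at Neuronal acetylcholine receptor; alpha4/beta2 (Homo sapiens), read by FLIPR and calcium flux (a higher number here means a larger maximal response, a lower number a smaller maximal response), compound 2 gives 71%, the second highest of the three numbers. Compound 3 gives 68%, within the scatter of compound 2, so the two cannot be told apart. For the measured compounds named here, compound 1 gives 110%, and the step of a number 39 percentage points lower from compound 1 to compound 2 (beyond the scatter) is the one measured step that bears on the change to be made.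

Compound 4, `O=C([C@H]1C[C@H]1F)N1CC2CC(C1)N2`, carries 2-fluorocyclopropyl in place of isopropyl on a carbonyl carbon. Going by the values given here, no measured step follows a fluorine or a three-membered ring, so the expectation rests on compounds 2 and 3 alone, whose values lie within the scatter of each other even though their groups on the carbonyl carbon differ. Compound 4 is therefore expected to stay close to compound 2, with the step of a number 1 percentage points lower from compound 2 to compound 4 (within the scatter) expected to lie within the scatter. For compound 4 the estimate is 70%, between 52% and 90%.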

Compound 4, largest response reached (Emax), in percent of the reference or control that the assay uses: 110%
Compound 4: middle estimate off by 40 percentage points, on the low side; measured number outside the range, above it.
By their numbers in this assay, from the lowest: compounds 3 and 2 (each within the scatter of the next); then compounds 1 and 4 (each within the scatter of the next).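

In this assay, for the compounds shown here, a group larger than ethyl on this carbonyl carbon need not lower the response, as the earlier compounds had suggested: the change from isopropyl to 2-fluorocyclopropyl gives a number 39 percentage points higher from compound 2 to compound 4 (beyond the scatter). Set against the ethyl group, the same 2-fluorocyclopropyl gives no change at the digits printed from compound 1 to compound 4 (within the scatter), so the response lost on going to isopropyl returns in full with a group of more heavy atoms, a three-membered ring and a fluorine. No available evidence accounts for this difference between the two groups.

The compounds shown leave open whether the ring or the fluorine carries the rise, which a plain cyclopropyl group on the same carbonyl carbon would help to separate. On these data alone, how the 2-fluorocyclopropyl group's two defined stereocentres matter also stays open, as its other stereoisomers do not appear here.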